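The source may hold more compounds than are shown below. What is called first, only, known or untested is meant among the compounds shown, and "the series" means these compounds.

Measured compounds and their values:

Compound 1 `CCOC(=O)C1=Cc2ccccc2OC1(OCc1cn(-c2ccc(F)cc2)nn1)C(F)(F)F` in a functional assay on MCF7 cells (Homo sapiens) for inhibition, read by MTT assay, with a stated time of 24 h (on this read-out higher numbers stand for weaker inhibition and lower numbers for stronger inhibition), gives 9100 nM. Compound 2 `CCOC(=O)C1=Cc2ccccc2OC1(OCc1cc(-c2ccc(C)cc2)no1)C(F)(F)F` gives > 150000 nM, a limit of the assay rather than a number. Compound 3 `Cc1ccc(-c2cc(COC3(C(F)(F)F)Oc4ccccc4C=C3C(=O)O)on2)cc1` gives 30100 nM.

Compound 3 holds the highest of the two numbers; its nearest neighbour is compound 1, whose number is lower. Among the measured compounds shown here, the only step measured, an at least 4.9-fold lower number from compound 2 to compound 3 (0.69 log units; beyond the scatter), concerns the ester alone. Compound 4 `O=C(O)C1=Cc2ccccc2OC1(OCc1cc(-c2ccc3ccccc3c2)no1)C(F)(F)F` differs from compound 3 by naphthalen-2-yl in place of 4-methylphenyl on an aromatic carbon. For the measured compounds named here, no measured step touches that aryl position, so no step beyond the scatter is expected in this assay. Compound 4 is therefore expected to give about 25000 nM, between 8000 nM and 90000 nM. The implied step, a 1.2-fold lower number from compound 3 to compound 4 (0.08 log units; within the scatter), is expected to lie within the scatter.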

Compound 4, half-maximal inhibitory concentration: > 150000 nM
Compound 4: no number, only a limit (the forecaster's own chance of this, stated with the estimate: 10%); at least 6.0-fold (0.77 log units) between middle value and limit.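

Naphthalen-2-yl in place of 4-methylphenyl on this aromatic carbon brings an at least 4.9-fold higher number from compound 3 to compound 4 (0.69 log units; beyond the scatter) in this assay. The earlier compounds shown here showed a step only at the ester, whereas here the carboxylic acid stays the same and the aryl group alone sets the read-out apart. The true size of this step stays unknown, since the value of compound 4 is a limit: the limit of > 150000 nM in this assay, at which 2 of the 4 values shown sit.

Open, as far as these compounds go, is how this position would read with a plain phenyl, or with a phenyl bearing an amine or a chlorine. Also open, from the compounds shown here alone, is whether any aryl group here could bring a number lower than that of compound 3.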